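This account rests on a few compounds, and the source may have more. Where it says the series, first, only, none or still open, it means among the compounds named here.

In a functional assay on HUVEC cells (Homo sapiens) for inhibition, read by ELISA and BrdU incorporation (a lower number here means a stronger inhibitor, a higher number a weaker inhibitor), compound 1 (`Cc1ccc(C(=O)Nc2cccc3cccnc23)c(O)c1`) gives 45 nM and compound 2 (`O=C(Nc1cccc2cccnc12)c1cc(Br)cnc1O`) gives 560 nM. Compound 2 thus holds the higher of the two numbers, and the gap between them lies beyond the scatter. Compound 3 (`Cc1cnc(O)c(C(=O)Nc2cccc3cccnc23)c1`) departs from compound 2 at one place: methyl in place of bromo on an aromatic carbon. Among the compounds with values here, no measured pair shows this exchange on its own. Compound 1, at 45 nM, also bears a methyl but differs from compound 2 in more than this one place, so it offers only a weak hint towards a lower number. A modest step down is therefore expected in this assay, near the edge of the scatter: the expected change is a 2.0-fold lower number from compound 2 to compound 3 (0.30 log units; within the scatter). Compound 3 is estimated at 280 nM, with an expected range from 80 nM to 900 nM.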

Compound 3, half-maximal inhibitory concentration: 1150 nM
Estimate against measurement, compound 3: 4.1-fold (0.61 log units) below; measured number outside the range, above it.
By their numbers in this assay, from the lowest: compound 1; then compound 2; then compound 3.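

In this assay, methyl in place of bromo on an aromatic carbon gives a 2.1-fold higher number from compound 2 to compound 3 (0.31 log units; beyond the scatter), so at this position, two atoms from the ring nitrogen and para to a hydroxy group, the exchange raises the number rather than lowering it. Within the data shown here, this pair is the first to show the exchange on its own, and the step is modest though beyond the scatter. The data shown offer nothing that accounts for the direction of this step.

The compounds shown leave open how other groups at this carbon, such as chloro, methoxy or an amine, would stand against bromo and methyl, and where a plain hydrogen there would fall. They also leave open whether the same exchange would move the number the same way on the core of compound 1.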